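Cyclopropyl for isopropyl on compound 3

The source may report more compounds than this note shows. Statements on the series, on what has been measured and on what is new or still open speak of the compounds shown alone.

In a functional assay on HCT-116 cells (Homo sapiens) for antiproliferative activity, read by MTT assay, with a stated time of 48 h (a lower number here means a stronger inhibitor, a higher number a weaker inhibitor), compound 1 (`COc1cc(-c2nnc3c(OC)cc(-c4ccc5[nH]ccc5c4)cn23)cc(OC)c1OC`) gives 108 nM and compound 2 (`COc1cc(-c2nnc3c(OC(C)C)cc(-c4ccc5[nH]ccc5c4)cn23)cc(OC)c1OC`) gives 939 nM while compound 3 (`COc1cc(-c2nnc3c(OC(C)C)cc(-c4ccc5c(ccn5C)c4)cn23)cc(OC)c1OC`) gives 402 nM as the middle number of the three. Compound 4 (`COc1cc(-c2nnc3c(OC4CC4)cc(-c4ccc5c(ccn5C)c4)cn23)cc(OC)c1OC`) alters compound 3 in one place, on an oxygen on an aromatic ring, with cyclopropyl in place of isopropyl (cyclopropyl in place of isopropyl on an oxygen on an aromatic ring).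

The most relevant measured change sits on that same oxygen. Isopropyl in place of methyl gave an 8.7-fold higher number from compound 1 to compound 2 (0.94 log units; beyond the scatter) as a modest step. The other measured step (a 2.3-fold lower number from compound 2 to compound 3 (0.37 log units; beyond the scatter)) is methyl in place of hydrogen on an aromatic nitrogen, a different place, so it says little here. Within the data shown here, no measured compound carries cyclopropyl, so the change is judged only loosely, and a small shift towards a lower number is expected at most. The expected step is a 1.3-fold lower number from compound 3 to compound 4 (0.13 log units; within the scatter) and its direction remains uncertain. In this assay compound 4 is estimated at 300 nM (expected range 120 nM to 750 nM).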

Compound 4, half-maximal inhibitory concentration: 135 nM
For compound 4 the middle estimate is 2.2-fold (0.35 log units) above the measured one; the measured number falls inside the stated range.
By their numbers in this assay, from the lowest: compounds 1 and 4 (each within the scatter of the next); then compound 3; then compound 2.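

In this assay, cyclopropyl in place of isopropyl on this oxygen gave a 3.0-fold lower number from compound 3 to compound 4 (0.47 log units; beyond the scatter). The earlier step on this oxygen exchanged methyl for isopropyl, two groups of different size, whereas isopropyl and cyclopropyl both hold 3 heavy atoms, all carbon, and differ in the three-membered ring; the count of atoms alone therefore does not fix the number at this position. Nothing available here accounts for this step.

The compounds shown leave open whether cyclopropyl on this oxygen would give a similar step with hydrogen instead of methyl on the aromatic nitrogen. They also leave open how this position would respond to a longer chain such as n-butyl, or to a chain ending in an amine.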